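Aryl ether exchange on two different cores

A few compounds are considered here, and "the series" means these few. Any claim that something is new, unique, unknown or untested is made for them only; others in the source may bear on it.

Compound 2 `O=[N+]([O-])c1ccc(Oc2ccccc2-c2ccc(S(=O)(=O)NCCNC(=S)Nc3cc(C(F)(F)F)cc(C(F)(F)F)c3)s2)cc1` and compound 1 `O=S(=O)(NCCNC(=S)Nc1cc(C(F)(F)F)cc(C(F)(F)F)c1)c1ccc(-c2ccccc2OCc2cccc(O)c2)s1` share one core. In a functional assay on HeLa cells (Homo sapiens) for inhibition, read by CCK-8 assay, with a stated time of 48 h (a higher number here means a weaker inhibitor, a lower number a stronger inhibitor), compound 2 gives 9900 nM and compound 1 gives 14900 nM. The change between them, (3-hydroxybenzyl in place of 4-nitrophenyl on an oxygen on an aromatic ring), produced a 1.5-fold higher number from compound 2 to compound 1 (0.18 log units; within the scatter). Compound 3 `COc1ccc(NC(=O)NCCNS(=O)(=O)c2ccc(-c3ccccc3Oc3ccc([N+](=O)[O-])cc3)s2)cc1` carries a different core; the difference between the two cores is not broken down here. In this assay compound 3 reaches only the limit of the assay, > 20000 nM, which is the limit of > 20000 nM in this assay, at which 1 of the 3 values shown sits. Compound 4 `COc1ccc(NC(=O)NCCNS(=O)(=O)c2ccc(-c3ccccc3OCc3cccc(O)c3)s2)cc1` is compound 3 with the same change, (3-hydroxybenzyl in place of 4-nitrophenyl on an oxygen on an aromatic ring), made at the same place. The step from compound 3 to compound 4 is expected to be similarly small, estimated as a step that the limit leaves unreadable from compound 3 to compound 4, because the same change gave a 1.5-fold higher number from compound 2 to compound 1 (0.18 log units; within the scatter). Compound 4 is therefore expected to show about 25000 nM in this assay, most likely reported again only as a limit.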

Compound 4, half-maximal inhibitory concentration: > 20000 nM
Compound 4: only a limit was reported; the forecaster's own chance of this, stated with the estimate: 70%; the middle value lies beyond the limit too.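

Going by these compounds alone, compound 3 and compound 4 are both reported only as limits in this assay, so no step between them can be read. Still open, on these data alone, is how the change from 4-nitrophenoxy to (3-hydroxybenzyl)oxy acts on the core of compound 3.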